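Benzyl swap with one measured value in the series

A few compounds are considered here, and "the series" means these few. Any claim that something is new, unique, unknown or untested is made for them only; others in the source may bear on it.

In a functional assay on G-361 cells (Homo sapiens) for antiproliferative activity, with a stated time of 72 h (a higher number here means a weaker inhibitor, a lower number a stronger inhibitor), compound 1 (`COc1cccc(CNc2ncnc3c2ncn3[C@@H]2O[C@H](CO)[C@@H](O)[C@H]2O)c1`) gives "not determined" (no result reported). Compound 3 (`COc1cccc(CNc2ncnc3c2ncn3[C@@H]2O[C@H](CO)[C@@H](O)[C@H]2O)c1OC`) likewise gives "not determined" (no result reported), so it has no single number on this read-out. Within the data shown here, compound 2 (`OC[C@H]1O[C@@H](n2cnc3c(NCc4ccc(Cl)cc4Cl)ncnc32)[C@H](O)[C@@H]1O`) gives 128000 nM, the only number available, and its aromatic ring carries chlorine. Compound 4 (`OC[C@H]1O[C@@H](n2cnc3c(NCc4ccc(F)c(Cl)c4)ncnc32)[C@H](O)[C@@H]1O`) follows from 3-chloro-4-fluorophenyl in place of 2,3-dimethoxyphenyl on a saturated chain carbon bound to a nitrogen on an aromatic ring. No measured step sizes this change. Compound 4 also has halogens on its ring, so in this assay it is expected to resemble compound 2, which gives 128000 nM. Compound 4 is estimated at 100000 nM, with an expected range of 40000 nM to 250000 nM.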

Compound 4, half-maximal inhibitory concentration: > 166000 nM
Compound 4: a limit, no number (the forecaster's own chance of this, stated with the estimate: 30%); at least 1.6-fold (0.22 log units) between middle value and limit.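

In this assay, compound 4 reads as a limit and not a number: the limit of > 166000 nM in this assay, at which 1 of the 4 values shown sits. Placing 3-chloro-4-fluorophenyl in place of 2,4-dichlorophenyl on a saturated chain carbon bound to a nitrogen on an aromatic ring gives an at least 1.2-fold higher number from compound 2 to compound 4 (0.11 log units; that floor lies within the scatter), so no order can be set between these two halogen patterns. The second halogen pattern at this position adds no second number to the series.

Steps to the methoxy compounds 1 and 3 cannot be read, which leaves halogen against methoxy open. As far as these compounds go, how an amine or a carboxylic acid on this ring would read also stays open.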